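Chloro Substitution Repeated on the Amide-Hydrogen Core

The source may hold more compounds than are shown below. What is called first, only, known or untested is meant among the compounds shown, and "the series" means these compounds.

Compound 1 `CN1C(=O)C2(C(C#N)=C(N)Oc3cc4oc(-c5ccccc5)cc(=O)c4c(O)c32)c2ccccc21`: > 50000 nM
Compound 2 `CN1C(=O)C2(C(C#N)=C(N)Oc3cc4oc(-c5ccccc5)cc(=O)c4c(O)c32)c2cc(Cl)ccc21`: 4340 nM
Compound 3 `N#CC1=C(N)Oc2cc3oc(-c4ccccc4)cc(=O)c3c(O)c2C12C(=O)Nc1ccccc12`: 36400 nM

In a functional assay on K562 cells (Homo sapiens) for antiproliferative activity, read by MTT assay, with a stated time of 48 h (on this read-out lower numbers stand for stronger inhibition and higher numbers for weaker inhibition), compound 1 reaches only a limit of the assay, > 50000 nM. Compound 2 gives 4340 nM in this assay. Compound 3 gives 36400 nM in this assay and so has the highest number among the two compounds with a number. Among the measured compounds shown here, the one further value, that of compound 1, is the limit of > 50000 nM in this assay, at which 1 of the 3 values shown sits.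

The two cores differ by hydrogen in place of methyl on an amide-type nitrogen in a ring, and that change made an at least 1.3-fold lower number from compound 1 to compound 3 (0.13 log units; that floor lies within the scatter). The change chloro in place of hydrogen on an aromatic carbon made an at least 11-fold lower number from compound 1 to compound 2 (1.06 log units; beyond the scatter), a large step whose true size is only a floor since compound 1 sits at a limit.

Compound 4 `N#CC1=C(N)Oc2cc3oc(-c4ccccc4)cc(=O)c3c(O)c2C12C(=O)Nc1cc(Cl)ccc12` is not yet measured. It differs from compound 3 by chloro in place of hydrogen on an aromatic carbon, the same change, at the same place, as between compound 1 and compound 2.

For compound 4 a step of comparable size is expected, a 10-fold lower number from compound 3 to compound 4 (1.02 log units; beyond the scatter), because an at least 11-fold lower number from compound 1 to compound 2 (1.06 log units; beyond the scatter) was large. Compound 4 is therefore estimated at 3500 nM, with a likely range from 1000 nM to 12000 nM.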

Compound 4, half-maximal inhibitory concentration: 9250 nM
Compound 4: middle estimate off by 2.6-fold (0.42 log units), on the low side; the measured number falls inside the stated range.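

In this assay, chloro in place of hydrogen on an aromatic carbon again lowered the number on the amide-hydrogen core, giving a 3.9-fold lower number from compound 3 to compound 4 (0.59 log units; beyond the scatter), so the direction of the change carried over from the core of compound 1 to the core of compound 3. The size of the step did not carry over unchanged, and the two steps stand apart: the same change on two cores in this assay, an at least 11-fold lower number (1.06 log units; beyond the scatter) from compound 1 to compound 2 and a 3.9-fold lower number (0.59 log units; beyond the scatter) from compound 3 to compound 4, at least 2.9-fold (0.46 log units) apart, beyond the scatter of two such steps Compound 1 stands at a limit, so the earlier step is only a floor, and the series shows neither how far apart the two steps truly lie nor why they differ: the limit of > 50000 nM in this assay, at which 1 of the 4 values shown sits.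

The compounds shown carry only hydrogen or chloro on this aromatic carbon, which leaves open whether fluoro, bromo, methoxy or an amine there would lower the number on either core. Going by these compounds, they carry only hydrogen or methyl on the amide-type nitrogen, so it also remains open how the chloro step would turn out with a longer chain, such as propyl, on that nitrogen.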